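Trimming the Aromatic Group at the Keto-Linked Carbon

The source may report more compounds than this note shows. Statements on the series, on what has been measured and on what is new or still open speak of the compounds shown alone.

Compound 1, `CCCCCCCCc1ccc(OCC(=O)Cn2ncc3ccccc32)cc1`: 2300 nM
Compound 2, `CCCCCCCCc1ccc(OCC(=O)Cn2ncc3cccnc32)cc1`: 1600 nM
Compound 3, `CCCCCCCCc1ccc(OCC(=O)Cn2cnc3cccnc32)cc1`: 410 nM

Within the data shown here, all three share the same core, a long chain on an aromatic ring joined through oxygen and a carbonyl to a saturated chain carbon that carries an aromatic group; only that group varies. In an assay on microsomes from brain for inhibition of Fatty-acid amide hydrolase 1 (Rattus norvegicus), read by fluorescence and HPLC, with a stated time of 60 min (a higher number here means a weaker inhibitor, a lower number a stronger inhibitor), compound 3 gives the lowest of the three numbers, 410 nM. Compound 2 is nearest, with a 3.9-fold lower number from compound 2 to compound 3 (0.59 log units; beyond the scatter), and compound 1 furthest, with a 5.6-fold lower number from compound 1 to compound 3 (0.75 log units; beyond the scatter). The change a 1.4-fold lower number from compound 1 to compound 2 (0.16 log units; within the scatter) stayed within the scatter.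

Compound 4, `CCCCCCCCc1ccc(OCC(=O)Cn2ncnn2)cc1`, makes a change of another kind: a group of 5 heavy atoms (1 carbon, 4 nitrogen; one five-membered aromatic ring with 4 hetero atoms) in place of a group of 9 heavy atoms (6 carbon, 3 nitrogen; one five-membered aromatic ring with 2 hetero atoms, one six-membered aromatic ring with 1 hetero atom), on a saturated chain carbon bound to a carbonyl carbon. Every measured step swapped one group of nine heavy atoms for another of the same shape, so none of them shows what happens when the six-membered ring is removed and only a small five-membered ring remains. The two steps beyond the scatter were modest, and both ran toward lower numbers as nitrogen replaced carbon within a group of unchanged size; that gives no guide for a much smaller group. A loss of activity seems the more likely outcome, with wide uncertainty. Compound 4 is therefore expected to give about 3000 nM in this assay, within 700 nM to 12000 nM. The expected step is a 7.3-fold higher number from compound 3 to compound 4 (0.86 log units; beyond the scatter).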

Compound 4, half-maximal inhibitory concentration: 10 nM
Estimate against measurement, compound 4: 300-fold (2.48 log units) above; measured number outside the range, below it.
By their numbers in this assay, from the lowest: compound 4; then compound 3; then compounds 2 and 1 (each within the scatter of the next).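

In this assay, swapping the larger two-ring groups for the much smaller 2H-tetrazol-2-yl gives a 41-fold lower number from compound 3 to compound 4 (1.61 log units; beyond the scatter), and the gaps to the other two compounds are wider still, at a 160-fold lower number from compound 2 to compound 4 (2.20 log units; beyond the scatter) and a 230-fold lower number from compound 1 to compound 4 (2.36 log units; beyond the scatter). Among these compounds, this shows that a six-membered aromatic ring is not needed on this saturated chain carbon bound to a carbonyl carbon for a low number, something the earlier compounds could not reveal, since all of them carried groups of 9 heavy atoms and their steps were modest at most. Nothing measured here accounts for the size of this gain.

From the compounds shown here alone, the change removes the six-membered ring and alters the number of ring nitrogens in a single move, so the share of each remains unknown; a single five-membered ring with fewer nitrogens, such as 1H-pyrazol-1-yl, at the same place would help separate the two. Going by these compounds, it also remains open whether 2H-tetrazol-2-yl would still give such a low number with a shorter chain in place of the long chain of the shared core.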